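Replacing a benzothiophene with a trifluoromethylphenyl on the thioether

A few compounds are considered here, and "the series" means these few. Any claim that something is new, unique, unknown or untested is made for them only; others in the source may bear on it.

Compound 1 `Cc1cc(N2CC[C@@H](C)[C@@H](N(C)c3ncnc4[nH]ccc34)C2)n2nc(SCc3ccccc3Br)nc2n1` gives 21300 nM in a functional assay on HGC-27 cells (Homo sapiens) for inhibition, read by MTT assay, with a stated time of 72 h; a lower number here means a stronger inhibitor, a higher number a weaker inhibitor.
Compound 2 `Cc1cc(N2CC[C@@H](C)[C@@H](N(C)c3ncnc4[nH]ccc34)C2)n2nc(SCc3csc4ccc(Cl)cc34)nc2n1` reaches only a limit of > 100000 nM in this assay.
Compound 3 `Cc1ccc(CSc2nc3nc(C)cc(N4CC[C@@H](C)[C@@H](N(C)c5ncnc6[nH]ccc56)C4)n3n2)cc1` gives 15200 nM in this assay.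

Among the compounds with values here, compound 2 is the one compound of the three for which no number is known, only a limit, and it is the one at the limit of > 100000 nM in this assay, at which 1 of the 3 values shown sits. Compound 4 `Cc1cc(N2CC[C@@H](C)[C@@H](N(C)c3ncnc4[nH]ccc34)C2)n2nc(SCc3ccc(C(F)(F)F)cc3)nc2n1` differs from it by 4-(trifluoromethyl)phenyl in place of 5-chloro-1-benzothiophen-3-yl on a saturated chain carbon bound to a sulfur. The measured steps that bear on this change are an at least 6.5-fold lower number from compound 2 to compound 3 (0.81 log units; beyond the scatter) and an at least 4.6-fold higher number from compound 1 to compound 2 (0.67 log units; beyond the scatter), both going beyond the scatter whenever the 5-chloro-1-benzothiophen-3-yl group is exchanged for a plain phenyl ring carrying a small substituent. Between the two phenyl compounds the step is a 1.4-fold lower number from compound 1 to compound 3 (0.15 log units; within the scatter), within the scatter. Compound 4 carries a 4-(trifluoromethyl)phenyl group, so it is expected to fall where compound 1 and compound 3 sit rather than at the limit, giving an expected step of an at least 5.0-fold lower number from compound 2 to compound 4 (0.69 log units; beyond the scatter). The estimate for compound 4 in this assay is therefore 20000 nM, with a range from 8000 nM to 60000 nM.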

Compound 4, half-maximal inhibitory concentration: 9540 nM
Beside the measured number, compound 4's estimate is 2.1-fold (0.32 log units) above it; low and high end bracket the measured number.
By their numbers in this assay, from the lowest: compounds 4, 3 and 1 (each within the scatter of the next, the first and the last beyond it). At a limit, above all of these: compound 2.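

In this assay, 4-(trifluoromethyl)phenyl in place of 5-chloro-1-benzothiophen-3-yl on a saturated chain carbon bound to a sulfur gives an at least 10-fold lower number from compound 2 to compound 4 (1.02 log units; beyond the scatter), so a third substituted phenyl group stands clear of the benzothiophene, and this step is large. Compound 2 is known only as a limit of the assay: the limit of > 100000 nM in this assay, at which 1 of the 4 values shown sits.

Trifluoromethyl in place of methyl on an aromatic carbon gives a 1.6-fold lower number from compound 3 to compound 4 (0.20 log units; within the scatter), which does not separate those two compounds, while 4-(trifluoromethyl)phenyl in place of 2-bromophenyl gives a 2.2-fold lower number from compound 1 to compound 4 (0.35 log units; beyond the scatter), the first modest step among the phenyl compounds. On these data alone, whether the 5-chloro-1-benzothiophen-3-yl group costs activity through its chlorine or through its five-membered aromatic ring stays open, since compound 2 differs from the others in both. As far as these compounds go, how a carboxylic acid or an amine on the phenyl ring would read in this assay also stays open.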